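This account rests on a few compounds, and the source may have more. Where it says the series, first, only, none or still open, it means among the compounds named here.

Within the data shown here, compound 1 `Cc1ccc(C2CC(=O)c3ccc(C)cc3O2)cc1` gives 500 nM in an in vitro assay on BTI-TN-5B1-4 cells for inhibition of Amine oxidase [flavin-containing] B (Homo sapiens) (on this read-out higher numbers stand for weaker inhibition and lower numbers for stronger inhibition), and holds the lowest of the two numbers so far; its nearest neighbour is compound 2 `Cc1ccc2c(c1)OC(c1ccccc1)CC2=O`, which in this assay gives 3620 nM. Among the measured compounds shown here, the single measured step in the set is a 7.2-fold higher number from compound 1 to compound 2 (0.86 log units; beyond the scatter), a hydrogen in place of a methyl on an aromatic carbon, and it moves the number toward weaker inhibition. Compound 3 `Cc1ccc(C2CC(=O)c3ccccc3O2)cc1` is not yet measured in this assay. It differs from compound 1 by hydrogen in place of methyl on an aromatic carbon. For the measured compounds named here, the measured step is the same kind of change carried out at another site, so it is the only guide here; whether the methyl removed in compound 3 matters as much as the one removed in compound 2 is not known from these data. A loss of the same direction, possibly smaller, is therefore expected, which corresponds to an expected step of a 3.0-fold higher number from compound 1 to compound 3 (0.48 log units; beyond the scatter). For compound 3 the estimate in this assay is 1500 nM, with a range from 500 nM to 5000 nM.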

Compound 3, half-maximal inhibitory concentration: 2070 nM
For compound 3 the middle estimate is 1.4-fold (0.14 log units) below the measured one; measured number inside the range.
By their numbers in this assay, from the lowest: compound 1; then compounds 3 and 2 (each within the scatter of the next).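

Removing the methyl from the ring that is part of the fused system is not neutral: in this assay the change gives a 4.1-fold higher number from compound 1 to compound 3 (0.62 log units; beyond the scatter) and so moves the number toward weaker inhibition. Together with a 7.2-fold higher number from compound 1 to compound 2 (0.86 log units; beyond the scatter) this shows two separate sites where hydrogen in place of methyl on an aromatic carbon produces a step beyond the scatter, so the low number of compound 1 does not rest on one methyl alone, and within these three compounds nothing goes against that reading. No measured information explains what either methyl contributes.

Still open, going by these compounds, is whether another group at this site on the fused system, such as ethyl, methoxy, chlorine or fluorine, would keep, improve or lose what the methyl provides, and whether moving the methyl to the other free aromatic carbons of that ring would matter. Also open, on these data alone, is what hydrogen at both sites would give, and so whether the two methyl contributions simply add or depend on each other.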